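Anilino variation on the shared core: compound 3

The compounds below may be only part of what the source reports. "The series", "measured", "known", "first", "only" and "open" are said of these compounds alone.

Compound 2 `COc1ccc(Nc2nc(SCc3cn(CC(=O)NC(=O)Nc4ccccn4)nn3)nc(-c3ccc(C(C)C)cc3)c2C#N)cc1` carries a 4-methoxyphenyl on a nitrogen on an aromatic ring. In a functional assay on MGC-803 cells (Homo sapiens) for inhibition, read by MTT assay, with a stated time of 72 h (a lower number here means a stronger inhibitor, a higher number a weaker inhibitor), compound 2 reaches only a limit of the assay, > 64000 nM. Compound 1 `CC(C)c1ccc(-c2nc(SCc3cn(CC(=O)NC(=O)Nc4ccccn4)nn3)nc(Nc3ccccc3F)c2C#N)cc1`, with a 2-fluorophenyl in that place, likewise gives only a limit in this assay, > 64000 nM. The step that the two limits leave unreadable from compound 1 to compound 2 is therefore not readable; the measured series shows only (the limit of > 64000 nM in this assay, at which 2 of the 2 values shown sit). Compound 3 `Cc1ccccc1Nc1nc(SCc2cn(CC(=O)NC(=O)Nc3ccccn3)nn2)nc(-c2ccc(C(C)C)cc2)c1C#N` is the next member: 2-methylphenyl in place of 4-methoxyphenyl on a nitrogen on an aromatic ring. Within the data shown here, no measured step bears on this change, as both anchors sit at the limit of > 64000 nM in this assay, at which 2 of the 2 values shown sit. With nothing to read, no step beyond the scatter is expected in this assay, and compound 3 is estimated to remain at 100000 nM, range 30000 nM to 300000 nM, most likely reported once more as a limit. The estimated step that the limit leaves unreadable from compound 2 to compound 3 is expected to lie within the scatter.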

Compound 3, half-maximal inhibitory concentration: 19000 nM
Estimate against measurement, compound 3: 5.3-fold (0.72 log units) above; the whole stated range lies above it.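

In this assay, among these compounds, this position gives the first readable change: 2-methylphenyl in place of 4-methoxyphenyl on a nitrogen on an aromatic ring gives an at least 3.3-fold lower number from compound 2 to compound 3 (0.52 log units; beyond the scatter). Methyl in place of fluoro on an aromatic carbon gives an at least 3.3-fold lower number from compound 1 to compound 3 (0.52 log units; beyond the scatter), so a change of this one group is enough to bring the series off the limit, with 2-fluorophenyl and 2-methylphenyl differing in nothing else. The step between the two other compounds cannot be read, and both remain at a limit of the assay: the limit of > 64000 nM in this assay, at which 2 of the 3 values shown sit.

From the compounds shown here alone, both readable steps are lower bounds, so their true sizes stay open. Also open, going by these compounds, is whether an ethyl or a chloro group in place of that methyl, or an amine on the same ring, would move the number further.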